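Ethoxy to methoxy on a shared core, measured in aorta

A few compounds are considered here, and "the series" means these few. Any claim that something is new, unique, unknown or untested is made for them only; others in the source may bear on it.

Of the compounds shown here, three have been measured in a functional assay on thoracic aorta (Rattus norvegicus, strain Wistar), with a stated time of 15 min; a lower number here means that less compound is needed, a higher number that more compound is needed for the effect. Compound 1 `COc1ccc(Cl)cc1C(C)NC(=O)N(C)S(=O)(=O)c1ccc(Cl)cc1` gives 20000 nM in this assay. Compound 2 `CCOc1ccc(Cl)cc1C(C)NC(=O)N(C)S(=O)(=O)c1ccc(Cl)cc1` gives 14600 nM in this assay. Compound 3 `CCOc1ccc(Br)cc1C(C)NC(=O)N(C)S(=O)(=O)c1ccc(C)cc1` gives 28600 nM in this assay. Compound 4 `COc1ccc(Br)cc1C(C)NC(=O)N(C)S(=O)(=O)c1ccc(C)cc1` has not yet been measured.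

Compound 1 and compound 2 differ in a single place (hydrogen in place of methyl on a saturated chain carbon bound to an oxygen on an aromatic ring), and the step was a 1.4-fold higher number from compound 2 to compound 1 (0.14 log units; within the scatter). Compound 2 and compound 3 differ in more than one place, so the difference between the two cores is not broken down here. The three measured values all lie within the usual scatter of one another, so none of them can be set apart from the others.

Compound 4 is related to compound 3 by hydrogen in place of methyl on a saturated chain carbon bound to an oxygen on an aromatic ring. This is the same change as from compound 2 to compound 1, at the same place, and it occurs twice among the compounds shown. The step from compound 3 to compound 4 is expected to be a 1.3-fold higher number from compound 3 to compound 4 (0.10 log units; within the scatter). That expectation rests on compound 2 and compound 1, whose step was a 1.4-fold higher number from compound 2 to compound 1 (0.14 log units; within the scatter), a step that stayed within the scatter. In this assay compound 4 is therefore estimated at 36000 nM, most likely between 18000 nM and 75000 nM.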

Compound 4, half-maximal effective concentration: 19100 nM
The estimate for compound 4 lay 1.9-fold (0.28 log units) above the measured number; low and high end bracket the measured number.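

On the second core in this assay, going from ethoxy to methoxy gave a 1.5-fold lower number from compound 3 to compound 4 (0.18 log units; within the scatter). Set beside the step on the first core, the change reads the same on both cores within the scatter: the same change on two cores in this assay, a 1.4-fold higher number (0.14 log units; within the scatter) from compound 2 to compound 1 and a 1.5-fold lower number (0.18 log units; within the scatter) from compound 3 to compound 4, 2.1-fold (0.31 log units) apart, within the scatter of two such steps. Within the data shown here, this shows that on these two cores the exchange of ethoxy for methoxy produced no step that can be told from the scatter, so a prediction of little visible effect carried over from one core to the other; it does not show that the change has no effect at all, that any small effect keeps its size or direction from core to core, or that the same would hold on a third core.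

The compounds shown leave open whether a larger change in the place of the ethoxy group, such as a longer chain like butoxy or a free hydroxyl, would give a step beyond the scatter. Among these compounds, they also leave open what the other differences between the two cores contribute separately, since no pair here differs only in the bromine or only in the methyl group, and whether a carboxylic acid or an amine at either of those places would move the number.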